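The source may report more compounds than this note shows. Statements on the series, on what has been measured and on what is new or still open speak of the compounds shown alone.

Measured so far in a functional assay on KB cells (Homo sapiens) for cytotoxicity; on this read-out higher numbers stand for weaker inhibition and lower numbers for stronger inhibition:
- compound 1 `NC(=O)c1cn(Cc2ccccc2)c2ncnc(N)c12`: 75000 nM.
- compound 2 `Cc1ccccc1Cn1cc(C(N)=O)c2c(N)ncnc21`: > 100000 nM, a limit of the assay and not a number.

Compound 2 stands at the weak end of the numbers shown, at the limit of > 100000 nM in this assay, at which 1 of the 2 values shown sits; only a limit is known for it. For the measured compounds named here, the single measured step, an at least 1.3-fold higher number from compound 1 to compound 2 (0.12 log units; that floor lies within the scatter), runs toward that limit, and its floor lies within the scatter, so it settles little about the methyl group.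

Compound 3 `Cc1ccc(Cn2cc(C(N)=O)c3c(N)ncnc32)cc1` is the unmeasured partner: 4-methylphenyl in place of 2-methylphenyl on a saturated chain carbon bound to an aromatic nitrogen. Going by the values given here, no measured step compares 2-methylphenyl with 4-methylphenyl, so nothing here fixes a size or a direction for this change, and both measured compounds sit near or at the top of the assay. A step of a number no higher from compound 2 to compound 3 (the limit leaves the size open) is expected, meaning no shift beyond the scatter. For compound 3 the estimate in this assay is 100000 nM, ranging from 40000 nM to 300000 nM, with a limit rather than a number about as likely as not.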

Compound 3, half-maximal inhibitory concentration: > 100000 nM
Compound 3: only a limit was reported (the forecaster's own chance of this, stated with the estimate: 50%); the middle value sits exactly at the limit.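

In this assay compound 3 gives > 100000 nM as a limit of the assay and not a number, so 4-methylphenyl at this position yields no readable value, just as 2-methylphenyl gave none. Against compound 1 the reading is an at least 1.3-fold higher number from compound 1 to compound 3 (0.12 log units; that floor lies within the scatter) and adds only a floor, while the step between compound 2 and compound 3 cannot be read, as both ends are limits. The methyl compounds now share one ceiling: the limit of > 100000 nM in this assay, at which 2 of the 3 values shown sit.

On these data alone, whether 2-methylphenyl and 4-methylphenyl differ at all in this assay stays open, and so does the size of any methyl effect relative to compound 1. Also open, as far as these compounds go, is whether an amine or a carboxylic acid on the aromatic ring, in place of methyl, would give a number rather than a limit.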